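This account rests on a few compounds, and the source may have more. Where it says the series, first, only, none or still open, it means among the compounds named here.

Compounds in this set share one core. Compound 1 is `O=C1CN(C2CCCC2)c2nc(Nc3ccc(N4CCCCC4)cn3)ncc2N1`, compound 2 is `CN1C(=O)CN(C2CCCC2)c2nc(Nc3ccc(N4CCCCC4)cn3)ncc21`, compound 3 is `CCN1C(=O)CN(C2CCCC2)c2nc(Nc3ccc(N4CCN(C)CC4)cn3)ncc21`, and the not yet measured compound 4 is `CCN1C(=O)CN(C2CCCC2)c2nc(Nc3ccc(N4CCCCC4)cn3)ncc21`. In an ADME assay on HEK293 cells (Homo sapiens) for inhibition, read by MTT assay, with a stated time of 48 h (a higher number here means a weaker inhibitor, a lower number a stronger inhibitor), compound 1 has "not determined" (no result reported). In this assay compound 2 gives only the limit, > 30000 nM. Compound 3 likewise gives only the limit of this assay, > 30000 nM. Among the measured compounds shown here, compound 3 thus stands at the limit together with compound 2, while compound 1 carries no number; the one piece of evidence in hand is the limit of > 30000 nM in this assay, at which 2 of the 3 values shown sit, which shows no graded step. For the measured compounds named here, no step between two compounds with numbers exists in this set.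

From compound 3 to compound 4 the change is piperidin-1-yl in place of 4-methylpiperazin-1-yl on an aromatic carbon. With both known values sitting at the limit, no step beyond the scatter is expected; the step is estimated as a step that the limit leaves unreadable from compound 3 to compound 4. Compound 4 is expected to give 40000 nM in this assay, with a range of 15000 nM to 100000 nM, and most likely to be reported again as a limit rather than a number.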

Compound 4, half-maximal inhibitory concentration: > 30000 nM
Compound 4 was reported as a limit; the forecaster's own chance of this, stated with the estimate: 75%; the middle value lies beyond the limit too.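

In this assay compound 4 gives > 30000 nM, which is a limit and not a number. Among the compounds shown here, compound 2 and compound 3 also stand at a limit, so no step from either to compound 4 can be read. The compounds shown leave open whether any change to the shared core gives a graded half-maximal inhibitory concentration in this assay.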